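This account rests on a few compounds, and the source may have more. Where it says the series, first, only, none or still open, it means among the compounds named here.

- Compound 1 `OCc1cn(Cc2ccc(Cl)cc2)c2ccccc12`: > 31600 nM
- Compound 2 `O=[N+]([O-])c1ccc(Cn2cc(CO)c3ccccc32)cc1`: > 31600 nM
- Compound 3 `OCc1cn(Cc2ccc(Cl)cc2)c2cc(F)ccc12`: > 31600 nM

These three entries from an ADME assay on T29 cells (Homo sapiens) for cytotoxicity, read by sulforhodamine B assay, with a stated time of 3 days (a higher number here means a weaker inhibitor, a lower number a stronger inhibitor), are limits and not exact numbers. Compound 1 stands at a limit, with no exact value to place it among the others. The same is true across the set: the limit of > 31600 nM in this assay, at which 3 of the 3 values shown sit.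

Compound 4 `Cc1cn(Cc2ccc(Cl)cc2)c2ccccc12` differs from compound 1 at one place: hydrogen in place of hydroxy on a saturated chain carbon bound to an aromatic carbon. Hydrogen takes the place of hydroxy on a saturated chain carbon bound to an aromatic carbon, turning hydroxymethyl into methyl.

Two measured steps offer the nearest guide, though neither changes this group. They are a step that the two limits leave unreadable from compound 1 to compound 2 and a step that the two limits leave unreadable from compound 1 to compound 3. Neither has a size that can be read, so neither points in a direction. With every value at the same limit, no step beyond the scatter is expected in this assay. The expected change is a number no higher from compound 1 to compound 4 (the limit leaves the size open). Compound 4 is estimated at 31600 nM, with an expected range of 12000 nM to 50000 nM.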

Compound 4, half-maximal inhibitory concentration: > 31600 nM
Compound 4: a limit, no number (the forecaster's own chance of this, stated with the estimate: 70%); the middle value sits exactly at the limit.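

No step can be read between compound 1 and compound 4, because both stand at a limit and not at an exact number: the limit of > 31600 nM in this assay, at which 4 of the 4 values shown sit.

In this assay the compounds shown leave open how far each lies from that limit, and so whether hydroxymethyl and methyl differ at all.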